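Replacing 2-Methylphenyl with 4-Fluorophenyl

The compounds below may be only part of what the source reports. "The series", "measured", "known", "first", "only" and "open" are said of these compounds alone.

compound 1 `Cc1cccc(Cn2cc(COc3ccc4c(=O)ccoc4c3)nn2)c1`: 16000 nM
compound 2 `Cc1ccccc1Cn1cc(COc2ccc3c(=O)ccoc3c2)nn1`: > 100000 nM
compound 3 `C#CCOc1ccc2c(=O)ccoc2c1`: > 100000 nM

In a functional assay on MDA-MB-231 cells (Homo sapiens) for cytotoxicity, read by MTT assay, with a stated time of 48 h (on this read-out lower numbers stand for stronger inhibition and higher numbers for weaker inhibition), compound 1 gives 16000 nM. For compound 2 the reading is only a limit, > 100000 nM. Compound 3 likewise stops at a limit, > 100000 nM. Compound 2 therefore stands at the limit of > 100000 nM in this assay, at which 2 of the 3 values shown sit, with no exact number. Compound 4 `O=c1ccoc2cc(OCc3cn(Cc4ccc(F)cc4)nn3)ccc12` differs from compound 2 by 4-fluorophenyl in place of 2-methylphenyl on a saturated chain carbon bound to an aromatic nitrogen. Among the measured compounds shown here, the only measured step touching this ring, an at least 6.2-fold higher number from compound 1 to compound 2 (0.79 log units; beyond the scatter), shows that the placement of a methyl shifted inhibition beyond the scatter, but no measured compound carries a fluorine, so the direction for compound 4 is uncertain. Compound 4 is expected to give 60000 nM, between 15000 nM and 250000 nM. The expected step of an at least 1.6-fold lower number from compound 2 to compound 4 (0.22 log units; that floor lies within the scatter) is modest at best and may again end at a limit.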

Compound 4, half-maximal inhibitory concentration: > 100000 nM
Compound 4: no number, only a limit; the forecaster's own chance of this, stated with the estimate: 45%; middle value at least 1.6-fold (0.22 log units) from the limit.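

In this assay compound 4 gives > 100000 nM and this is a limit, not a number. The change to 4-fluorophenyl gives an at least 6.2-fold higher number from compound 1 to compound 4 (0.79 log units; beyond the scatter), so this ring, like the 2-methylphenyl ring, falls short of the 3-methylphenyl ring of compound 1, while the step between the two limits cannot be read. Among the compounds shown here, compound 1 is now the only benzyl compound here with an exact number, and the other values sit at one limit: the limit of > 100000 nM in this assay, at which 3 of the 4 values shown sit.

The compounds shown leave open how a ring carrying an amine or a carboxylic acid would read. As far as these compounds go, how a longer chain at this place would read also stays open.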